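The source may hold more compounds than are shown below. What is called first, only, known or untested is meant among the compounds shown, and "the series" means these compounds.

Measured so far in a functional assay on HCT-116 cells (Homo sapiens) for antiproliferative activity, read by MTT assay, with a stated time of 48 h; on this read-out lower numbers stand for stronger inhibition and higher numbers for weaker inhibition:
compound 1, `N#CC1=C(N)Oc2c(c3nc4ccccc4nc3c3ccccc23)C12C(=O)N(Cc1cnnn1-c1ccccc1Br)c1ccccc12`, a limit of the assay at > 50000 nM.
compound 2, `N#CC1=C(N)Oc2c(c3nc4ccccc4nc3c3ccccc23)C12C(=O)N(Cc1cnnn1-c1cccc(Br)c1)c1ccccc12`, a limit of the assay at > 50000 nM.
compound 3, `CCOc1ccc(-n2nncc2CN2C(=O)C3(C(C#N)=C(N)Oc4c3c3nc5ccccc5nc3c3ccccc43)c3ccccc32)cc1`, a limit of the assay at > 50000 nM.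

Compound 3 stands at the limit of this assay, with no number behind it, and the same holds for compound 1 and compound 2: the limit of > 50000 nM in this assay, at which 3 of the 3 values shown sit. None of the three values can be set in order against another. The changes of the aryl group on the aromatic nitrogen that connect the measured compounds, a step that the two limits leave unreadable from compound 1 to compound 2, a step that the two limits leave unreadable from compound 1 to compound 3 and a step that the two limits leave unreadable from compound 2 to compound 3, are therefore all of unreadable size.

Compound 4, `Cc1ccc(C)c(-n2nncc2CN2C(=O)C3(C(C#N)=C(N)Oc4c3c3nc5ccccc5nc3c3ccccc43)c3ccccc32)c1`, differs from compound 3 by 2,5-dimethylphenyl in place of 4-ethoxyphenyl on an aromatic nitrogen. The three measured steps are the only ones that bear on this change of the aryl group, and each of them is hidden by the limit. No direction or size can be read from them. The expectation is that compound 4 also gives only the limit in this assay, so that the step from compound 3 is expected as a step that the limit leaves unreadable from compound 3 to compound 4. Compound 4 is estimated at 80000 nM, in the range 25000 nM to 300000 nM.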

Compound 4, half-maximal inhibitory concentration: > 50000 nM
Compound 4 was reported as a limit (the forecaster's own chance of this, stated with the estimate: 80%); the middle value is on the limit's open side.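

In this assay compound 4 gives > 50000 nM, a limit of the assay and not a number, so its steps from compound 1, compound 2 and compound 3 cannot be read. The compounds shown leave open whether any of these aryl groups on the aromatic nitrogen differs from another in this assay.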